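One Inverted Stereocentre on the Core of Compound 1

The compounds below may be only part of what the source reports. "The series", "measured", "known", "first", "only" and "open" are said of these compounds alone.

Of the compounds shown here, two have so far been measured in a functional assay on A549 cells (Homo sapiens) for inhibition, read by CCK-8 assay, with a stated time of 72 h; on this read-out higher numbers stand for weaker inhibition and lower numbers for stronger inhibition. Compound 1, with the structure `Cc1cc(=O)cc2c3c1[C@@H](O)[C@H]1[C@@H]3[C@]3(CC2)C(=O)O[C@@H]1CC3C`, stands at the highest of the two numbers: in this assay compound 1 gives 10300 nM. The other measured compound, compound 2, has the structure `Cc1cc(=O)cc2c3c1C[C@H]1[C@@H]3[C@]3(C=C2)C(=O)O[C@@H]1CC3C`, and in this assay compound 2 gives 1000 nM, a number that sits well beyond the usual scatter away from compound 1. Going by the values given here, no pair of measured compounds differs in only one place, so no single change has yet been tied to a change in the read-out.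

Compound 3, with the structure `Cc1cc(=O)cc2c3c1[C@H](O)[C@H]1[C@@H]3[C@]3(CC2)C(=O)O[C@@H]1CC3C`, has not been measured. Set against compound 1 it differs in this way: the two compounds have the same atoms and bonds; at least one stereo element is drawn with a configuration in one of them and without one in the other: 1 of 6 stereo elements differ; a stereocentre at a saturated ring carbon is drawn S in compound 1 and R in compound 3. Everything else in the molecule is the same. Among the compounds with values here, with no measured step of this kind to lean on, the expectation for compound 3 is a modest move from compound 1, most likely within the scatter, which is what the expected step of a 1.3-fold lower number from compound 1 to compound 3 (0.11 log units; within the scatter) means. Compound 3 is accordingly expected to give about 8000 nM in this assay, with a plausible range from 2500 nM to 25000 nM.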

Compound 3, half-maximal inhibitory concentration: 2400 nM
Beside the measured number, compound 3's estimate is 3.3-fold (0.52 log units) above it; measured number outside the range, below it.
By their numbers in this assay, from the lowest: compound 2; then compound 3; then compound 1.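

Going by these compounds alone, this is the first step between measured compounds that differ in only one place, so a change in the read-out can now be tied to a single change in the structure. In this assay, going from S to R at a saturated ring carbon gives a 4.3-fold lower number from compound 1 to compound 3 (0.63 log units; beyond the scatter), a modest step but one beyond the usual scatter, even though the two compounds share the same atoms and bonds. The read-out therefore responds to the configuration at this one position and not only to which groups the molecule carries, with one caution attached to the comparison: the fact that one of compounds 1 and 3 is drawn with a defined configuration and the other without, at the place where they differ.

The compounds shown leave open whether this preference for the R drawing holds when the group on this carbon is something else, such as an amine or a methoxy group, since only one kind of substituent appears there in this pair. They also leave open whether the same inversion would give a step of similar size on a core with other changes elsewhere, as a single pair cannot show how far the effect carries.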